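Furan-2-yl against furan-3-yl in an adenosine receptor A2b series

The compounds below may be only part of what the source reports. "The series", "measured", "known", "first", "only" and "open" are said of these compounds alone.

Measured so far in an assay on membranes from HEK293 cells for displacement of a labelled ligand from adenosine receptor A2b (Homo sapiens), read by scintillation counting, with a stated time of 30 min; a higher number here means a weaker inhibitor, a lower number a stronger inhibitor:
compound 1 `CC1=C(C(=O)OCc2ccccc2)C(c2ccco2)NC(=O)N1` gives 887 nM
compound 2 `CC1=C(C(=O)OCc2ccccc2)C(c2ccoc2)NC(=O)N1` gives 6650 nM
compound 3 `CC1=C(c2ncc(C)o2)C(c2ccco2)NC(=O)N1` gives 905 nM

Compound 1 and compound 2 differ by furan-3-yl in place of furan-2-yl on a saturated ring carbon, and the step of a 7.5-fold higher number from compound 1 to compound 2 (0.87 log units; beyond the scatter). Compound 3 carries a 5-methyl-1,3-oxazol-2-yl group where compound 1 carries a large group; the difference between the two cores is not broken down here. In this assay compound 3 and compound 1 give numbers within the scatter of each other.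

Compound 4 `CC1=C(c2ncc(C)o2)C(c2ccoc2)NC(=O)N1` is not yet measured. It relates to compound 3 by furan-3-yl in place of furan-2-yl on a saturated ring carbon. This is the same kind of change as from compound 1 to compound 2, not the same: the place is next to the ring atom that bears a 5-methyl-1,3-oxazol-2-yl group, whereas before it was next to the ring atom that bears a large group. Among the measured compounds shown here, a step of about a 6.1-fold higher number from compound 3 to compound 4 (0.78 log units; beyond the scatter) is expected for compound 4 in this assay, resting on the single precedent a 7.5-fold higher number from compound 1 to compound 2 (0.87 log units; beyond the scatter). Compound 4 is therefore estimated at 5500 nM, with a range from 2000 nM to 15000 nM.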

Compound 4, inhibition constant: 801 nM
For compound 4 the middle estimate is 6.9-fold (0.84 log units) above the measured one; the whole stated range lies above it.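

In this assay, furan-3-yl in place of furan-2-yl on the saturated ring carbon gives a 1.1-fold lower number from compound 3 to compound 4 (0.05 log units; within the scatter), so the loss seen on the core of compound 1 does not appear on the core of compound 3. The change therefore does not carry over in size between these two cores: the same change on two cores in this assay, a 7.5-fold higher number (0.87 log units; beyond the scatter) from compound 1 to compound 2 and a 1.1-fold lower number (0.05 log units; within the scatter) from compound 3 to compound 4, 8.5-fold (0.93 log units) apart, beyond the scatter of two such steps

This rests on one pair per core and shows that the effect of the furan swap depends on the core, but it does not show which feature of the two cores is responsible.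

Still open, as far as these compounds go, is whether a methyl ester, a primary amide or a carboxylic acid in place of the 5-methyl-1,3-oxazol-2-yl group would follow the pair of compound 1 and compound 2 or that of compound 3 and compound 4. Also open, from the compounds shown here alone, is how a thiophene in place of either furan would behave on these cores.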